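From propylcarbamoyl to 2-ethoxyethoxy on compound 3

The source may report more compounds than this note shows. Statements on the series, on what has been measured and on what is new or still open speak of the compounds shown alone.

In an ADME assay on SH-SY5Y cells (Homo sapiens) for cytotoxicity, read by MTT assay, with a stated time of 48 h (on this read-out lower numbers stand for stronger inhibition and higher numbers for weaker inhibition), compound 3 `CCCNC(=O)c1ccc(/C=C/C(=O)c2ccc(OC)cc2O)cc1` stands at > 100000 nM as a limit of the assay and not a number. Compound 1 `COc1ccc(C(=O)/C=C/c2ccc(C(=O)N3CCCC3)cc2)c(O)c1` gives > 100000 nM as a limit. Compound 2 `COc1ccc(C(=O)/C=C/c2ccc(C(=O)N3CCCCC3)cc2)c(O)c1` gives > 100000 nM as a limit too. Compound 4 `CCOCCOc1ccc(/C=C/C(=O)c2ccc(OC)cc2O)cc1` carries 2-ethoxyethoxy in place of propylcarbamoyl on an aromatic carbon, para to a large group (2-ethoxyethoxy in place of propylcarbamoyl on an aromatic carbon). The measured steps a step that the two limits leave unreadable from compound 1 to compound 3 and a step that the two limits leave unreadable from compound 2 to compound 3 bear on it but give no size. Among the measured compounds shown here, with every value so far at the limit of > 100000 nM in this assay, at which 3 of the 3 values shown sit, no step beyond the scatter is expected on these data. The estimated step is a number no higher from compound 3 to compound 4 (the limit leaves the size open) and no larger change is expected. Compound 4 is expected at 100000 nM within an estimated range from 40000 nM to 250000 nM and may again yield only a limit.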

Compound 4, half-maximal inhibitory concentration: > 100000 nM
Compound 4 was reported as a limit; the forecaster's own chance of this, stated with the estimate: 70%; the middle value sits exactly at the limit.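

No step can be read between compound 4 and compound 1, compound 2 or compound 3 in this assay, as each result is only a limit: the limit of > 100000 nM in this assay, at which 4 of the 4 values shown sit.

The compounds shown leave open whether exchanging these groups on the shared core changes the read-out at all, and by how much.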